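Working notes: the step from compound 2 to compound 3

The source may report more compounds than this note shows. Statements on the series, on what has been measured and on what is new or still open speak of the compounds shown alone.

- compound 1 `CCC[S+]([O-])CCCCN=C=S`: 5640 nM
- compound 2 `CCCC[S+]([O-])CCCCN=C=S`: 5150 nM
- compound 3 `[O-][S+](CCCCN=C=S)Cc1cccs1`: not yet measured

In an ADME assay on Vero cells (Chlorocebus sabaeus) for cytotoxicity, read by MTT assay, with a stated time of 72 h (on this read-out lower numbers stand for stronger inhibition and higher numbers for weaker inhibition), compound 2 stands level with compound 1, with a 1.1-fold lower number from compound 1 to compound 2 (0.04 log units; within the scatter). The next change is thiophen-2-yl in place of propyl on a saturated chain carbon bound to a sulfur. Among the compounds with values here, the one measured step bearing on it, a 1.1-fold lower number from compound 1 to compound 2 (0.04 log units; within the scatter), is methyl in place of hydrogen on the chain and stays within the scatter. Within the data shown here, no measured step covers a ring, so the guide is weak, and no shift beyond the scatter is expected in either direction. The expected step is a 1.1-fold lower number from compound 2 to compound 3 (0.03 log units; within the scatter). Compound 3 is estimated at 4800 nM, with an expected range of 2000 nM to 10000 nM.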

Compound 3, half-maximal inhibitory concentration: 6220 nM
Compound 3: the middle estimate sits 1.3-fold (0.11 log units) below what was measured; the range from low to high includes it.
By their numbers in this assay, from the lowest: compounds 2, 1 and 3 (each within the scatter of the next).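

In this assay, the saturated chain carbon bound to a sulfur carries a thiophen-2-yl ring as well as a plain chain, with a 1.2-fold higher number from compound 2 to compound 3 (0.08 log units; within the scatter) and with a 1.1-fold higher number from compound 1 to compound 3 (0.04 log units; within the scatter) as the two steps. Both stay within the scatter, so the read-out stays level across this change, which the earlier chain-only step could not show. No evidence at hand bears on this result.

Still open, going by these compounds, is whether a phenyl ring, a longer chain or an amine at this place would move the number beyond the scatter.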